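Swapping trifluoromethoxy for methyl on the aryl ring

A few compounds are considered here, and "the series" means these few. Any claim that something is new, unique, unknown or untested is made for them only; others in the source may bear on it.

Compound 1 `COc1ccc(C(C)NC(=O)/N=C(\N)NCCCc2sc(N)nc2C)cc1` gives 0.91 in a functional assay on Right cardiac atrium for agonist activity at histamine H2 receptor (Cavia porcellus), with a stated time of 30 min, in the presence of a further agent that is not named here; a lower number here means a smaller maximal response, a higher number a larger maximal response. Compound 2 `Cc1nc(N)sc1CCCN/C(N)=N/C(=O)NC(C)c1ccc(Br)cc1` gives 0.87, and compound 3 `Cc1nc(N)sc1CCCN/C(N)=N/C(=O)NC(C)c1ccc(OC(F)(F)F)cc1` gives 0.61, the lowest of the three, with both others standing above it beyond the scatter. Compound 4 `Cc1ccc(C(C)NC(=O)/N=C(\N)NCCCc2sc(N)nc2C)cc1` has not yet been measured. methyl in place of trifluoromethoxy on an aromatic carbon The change sits on an aromatic carbon of a six-membered aromatic ring of carbon only, para to a large group. Among the compounds with values here, two measured steps bear on it, both ending at the trifluoromethoxy compound: a number 0.30 lower from compound 1 to compound 3 (beyond the scatter) and a number 0.26 lower from compound 2 to compound 3 (beyond the scatter), each modest and beyond the scatter. Putting a small methyl in that place is expected to undo a step of about that size, so the expected step is a number 0.26 higher from compound 3 to compound 4 (beyond the scatter). Compound 4 is therefore estimated at 0.87, within a range of 0.72 to 0.98.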

Compound 4, intrinsic activity: the largest response reached, as a fraction of the reference agonist's: 0.85
Compound 4: the middle estimate sits 0.020 above what was measured; the measured number falls inside the stated range.
By their numbers in this assay, from the lowest: compound 3; then compounds 4, 2 and 1 (each within the scatter of the next).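

In this assay, methyl in place of trifluoromethoxy at this position on the ring gives a clear change (a number 0.24 higher from compound 3 to compound 4 (beyond the scatter)). Methyl cannot be told apart from bromo (a number 0.020 lower from compound 2 to compound 4 (within the scatter)) or from methoxy (a number 0.060 lower from compound 1 to compound 4 (within the scatter)). Among these four compounds, then, only the trifluoromethoxy compound stands apart, while three different groups at this position give matching maximal responses. As far as these compounds go, whether an amine, a carboxylic acid or a longer chain at this position would keep the response high remains open. Nothing measured here explains why trifluoromethoxy stands apart.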